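From ethoxycarbonyl to carboxy at compound 4

The source may hold more compounds than are shown below. What is called first, only, known or untested is meant among the compounds shown, and "the series" means these compounds.

Measured in a functional assay on Rec1 cells (Homo sapiens) for inhibition, read by luminescence and CellTiter-Glo, with a stated time of 72 h; on this read-out lower numbers stand for stronger inhibition and higher numbers for weaker inhibition:
Compound 1 `O=C(O)c1cc(-c2ccc(Oc3ccccc3)cc2)nn1C1CCCN(C(=O)CCl)C1` gives 2200 nM
Compound 2 `C/C=C/C(=O)N1CCCC(n2nc(-c3ccc(Oc4ccccc4)cc3)cc2C(=O)OCC)C1` gives 5100 nM
Compound 3 `C=CC(=O)N1CCCC(n2nc(-c3ccc(Oc4ccccc4)cc3)cc2C(=O)OCC)C1` gives 13800 nM

Compound 2 at 5100 nM stands in the middle of the three, with compound 1 lower and compound 3 higher. Compound 4 `C/C=C/C(=O)N1CCCC(n2nc(-c3ccc(Oc4ccccc4)cc3)cc2C(=O)O)C1` differs from compound 2 by hydrogen in place of ethyl on an oxygen next to a carbonyl group with hydrogen in place of ethyl on an oxygen next to a carbonyl group. Among the measured compounds shown here, no measured step covers this change. For the measured compounds named here, the one step available, a 2.7-fold higher number from compound 2 to compound 3 (0.43 log units; beyond the scatter), lies elsewhere, at vinyl in place of prop-1-en-1-yl on a carbonyl carbon. Compound 1 also carries carboxy at 2200 nM but differs elsewhere too. No step beyond the scatter is therefore expected in this assay, though a lower number seems likelier. The expected change is a 1.3-fold lower number from compound 2 to compound 4 (0.13 log units; within the scatter) as estimated. For compound 4 the estimate is 3800 nM with 1500 nM to 10000 nM as the expected range.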

Compound 4, half-maximal inhibitory concentration: 31000 nM
Beside the measured number, compound 4's estimate is 8.2-fold (0.91 log units) below it, outside the stated range (above it).
By their numbers in this assay, from the lowest: compound 1; then compound 2; then compound 3; then compound 4.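

In this assay, hydrogen in place of ethyl on an oxygen next to a carbonyl group is not a silent change, giving a 6.1-fold higher number from compound 2 to compound 4 (0.78 log units; beyond the scatter). Carboxy alone therefore does not go with a low number, and with carboxy kept, prop-1-en-1-yl in place of chloromethyl on a carbonyl carbon gives a 14-fold higher number from compound 1 to compound 4 (1.15 log units; beyond the scatter). Nothing measured here explains either step. On these data alone, it remains open how a methyl ester or a primary amide would read at this place, and how chloromethyl would read alongside ethoxycarbonyl.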